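Adding a Methoxy Group to Compound 2

The source may report more compounds than this note shows. Statements on the series, on what has been measured and on what is new or still open speak of the compounds shown alone.

Compound 1 `COc1cccc(-c2cc(=O)c3cc(NC(C)=O)ccc3o2)c1`: > 404000 nM, a limit of the assay
Compound 2 `CC(=O)Nc1ccc2oc(-c3cccc(F)c3)cc(=O)c2c1`: 240000 nM
Compound 3 `CC(=O)Nc1ccc2oc(-c3ccc(F)cc3)cc(=O)c2c1`: 203000 nM

All three results come from an ADME assay on MT4 cells (Homo sapiens) for cytotoxicity, read by MTT assay, with a stated time of 4 days; a higher number here means that more compound is tolerated, a lower number that less compound is tolerated. Compound 2 has a measured number, and compound 3 sits close to it, with a 1.2-fold lower number from compound 2 to compound 3 (0.07 log units; within the scatter). The value of compound 1 is a limit and not a number.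

Compound 4 `COc1c(-c2cccc(F)c2)oc2ccc(NC(C)=O)cc2c1=O` differs from compound 2 by one change: methoxy in place of hydrogen on an aromatic carbon. It has methoxy in place of hydrogen on an aromatic carbon, ortho to a 3-fluorophenyl group.

Among the measured compounds shown here, two measured steps bear on this, though neither makes this exact change. One involves methoxy at a different place, with an at least 1.6-fold lower number from compound 1 to compound 2 (0.22 log units; that floor lies within the scatter). For compound 1 that step is only a floor because of the limit of > 404000 nM in this assay, at which 1 of the 3 values shown sits. The other is the step from compound 2 to compound 3 given above, which moves the fluorine. Neither step goes beyond the scatter, so no clear shift is expected here, though this remains uncertain. The estimate amounts to a 1.2-fold lower number from compound 2 to compound 4 (0.08 log units; within the scatter), and this expected step stays within the usual scatter. For compound 4 the estimated value is 200000 nM, with an expected range from 60000 nM to 400000 nM.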

Compound 4, half-maximal cytotoxic concentration: 210000 nM
Compound 4: middle estimate off by 1.1-fold (0.02 log units), on the low side; low and high end bracket the measured number.
By their numbers in this assay, from the lowest: compounds 3, 4 and 2 (each within the scatter of the next). At a limit, above all of these: compound 1.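

In this assay, methoxy in place of hydrogen on this aromatic carbon, ortho to a 3-fluorophenyl group, gives a 1.1-fold lower number from compound 2 to compound 4 (0.06 log units; within the scatter). Among the compounds shown here, this is the first direct reading at this carbon, two atoms from the ring oxygen, and it shows that a methoxy group can sit here without a clear shift in the amount of compound tolerated, whereas the earlier steps concerned only other places. Compound 1 remains a limit and not a number: the limit of > 404000 nM in this assay, at which 1 of the 4 values shown sits.

As far as these compounds go, whether another group on this carbon, such as an amine, a carboxylic acid or a longer chain, would also leave the number within the scatter stays open. So does whether methoxy here would behave the same way alongside the 4-fluorophenyl group of compound 3.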